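This account rests on a few compounds, and the source may have more. Where it says the series, first, only, none or still open, it means among the compounds named here.

Compound 1 `CCCCN(C)Cc1c(C(F)(F)F)nc2n(-c3c(C)cc(C)cc3C)c(Cl)cn12` gives 310 nM in an assay on cells for displacement of a labelled ligand from corticotropin-releasing factor receptor 1 (Homo sapiens), with a stated time of 100 min; a lower number here means a stronger inhibitor, a higher number a weaker inhibitor. Compound 2 `C=CCN(CC=C)Cc1c(C(F)(F)F)nc2n(-c3c(C)cc(C)cc3C)c(Cl)cn12` gives 13 nM in this assay, and compound 3 `C=C(C)CN(CC)Cc1c(C(F)(F)F)nc2n(-c3c(C)cc(C)cc3C)c(Cl)cn12` gives 67 nM, the second highest of the three numbers. The steps of a 24-fold lower number from compound 1 to compound 2 (1.38 log units; beyond the scatter) and a 4.6-fold lower number from compound 1 to compound 3 (0.67 log units; beyond the scatter) show that the substituents on the amine move the number, and a 5.2-fold higher number from compound 2 to compound 3 (0.71 log units; beyond the scatter) separates the two unsaturated amines. Compound 4 `CCN(Cc1c(C(F)(F)F)nc2n(-c3c(C)cc(C)cc3C)c(Cl)cn12)CC1CCC1` carries cyclobutyl in place of 1-methylethenyl on a saturated chain carbon bound to an amine nitrogen. Within the data shown here, no measured step exchanges an alkene for a saturated ring, so the change is expected to stay within the scatter, a 1.3-fold lower number from compound 3 to compound 4 (0.13 log units; within the scatter). Compound 4 is accordingly estimated at 50 nM in this assay, with a range from 15 nM to 160 nM.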

Compound 4, inhibition constant: 16 nM
Estimate against measurement, compound 4: 3.1-fold (0.49 log units) above; the range from low to high includes it.
By their numbers in this assay, from the lowest: compounds 2 and 4 (each within the scatter of the next); then compound 3; then compound 1.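

In this assay cyclobutyl in place of 1-methylethenyl on a saturated chain carbon bound to an amine nitrogen gives a 4.2-fold lower number from compound 3 to compound 4 (0.62 log units; beyond the scatter) so a double bond is not needed at this place. Against diallylamino the step is a 1.2-fold higher number from compound 2 to compound 4 (0.09 log units; within the scatter) and the two amines cannot be ordered, while against butyl(methyl)amino the step is a 19-fold lower number from compound 1 to compound 4 (1.29 log units; beyond the scatter) and the difference stands. Nothing available explains these steps.

Open, from the compounds shown here alone, is whether the ring itself matters: the saturated open chain 2-methylpropyl on the same nitrogen would test that. Cyclopropylmethyl and cyclopentylmethyl would show how the number follows ring size.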